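Vinyl in Place of Prop-1-en-1-yl on a Weak Series

This account rests on a few compounds, and the source may have more. Where it says the series, first, only, none or still open, it means among the compounds named here.

Measured in a functional assay on Maver1 cells (Homo sapiens) for inhibition, read by luminescence and CellTiter-Glo, with a stated time of 72 h; a higher number here means a weaker inhibitor, a lower number a stronger inhibitor:
compound 1 `C/C=C/C(=O)N1CCCC(n2nc(-c3ccc(Oc4ccccc4)cc3)cc2C(=O)OCC)C1`, 19600 nM;
compound 2 `C=CC(=O)N1CCCC(n2nc(-c3ccc(Oc4ccccc4)cc3)cc2C(=O)OCC)C1`, which reaches only the assay limit of > 60000 nM;
compound 3 `C/C=C/C(=O)N1CCCC(n2nc(-c3ccc(Oc4ccccc4)cc3)cc2CO)C1`, which likewise stops at the assay limit of > 60000 nM.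

The change vinyl in place of prop-1-en-1-yl on a carbonyl carbon gives an at least 3.0-fold higher number from compound 1 to compound 2 (0.48 log units; beyond the scatter). The change hydroxymethyl in place of ethoxycarbonyl on an aromatic carbon gives an at least 3.0-fold higher number from compound 1 to compound 3 (0.48 log units; beyond the scatter). Both end at the limit of > 60000 nM in this assay, at which 2 of the 3 values shown sit, so only lower bounds of the loss are known.

Compound 4 `C=CC(=O)N1CCCC(n2nc(-c3ccc(Oc4ccccc4)cc3)cc2CO)C1` is still to be measured. It arises from compound 3 by vinyl in place of prop-1-en-1-yl on a carbonyl carbon, the same kind of change seen from compound 1 to compound 2, at a place described in identical words. Since compound 3 already sits at the limit, compound 4 is expected to remain there, an estimated step that the limit leaves unreadable from compound 3 to compound 4. The estimate for compound 4 in this assay is 120000 nM, between 40000 nM and 400000 nM.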

Compound 4, half-maximal inhibitory concentration: 30500 nM
For compound 4 the middle estimate is 3.9-fold (0.59 log units) above the measured one; the measured number lies below the stated range.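

In this assay, vinyl in place of prop-1-en-1-yl on a carbonyl carbon gives an at least 1.9-fold lower number from compound 3 to compound 4 (0.29 log units; that floor lies within the scatter), so this change does not carry from one core to the other as a fixed step: the same change on two cores in this assay, an at least 3.0-fold higher number (0.48 log units; beyond the scatter) from compound 1 to compound 2 and an at least 1.9-fold lower number (0.29 log units; that floor lies within the scatter) from compound 3 to compound 4, at least 6.0-fold (0.77 log units) apart, beyond the scatter of two such steps. Hydroxymethyl in place of ethoxycarbonyl, which gives an at least 1.9-fold lower number from compound 2 to compound 4 (0.29 log units; that floor lies within the scatter), likewise depends on what else the compound carries: the same change on two cores in this assay, an at least 3.0-fold higher number (0.48 log units; beyond the scatter) from compound 1 to compound 3 and an at least 1.9-fold lower number (0.29 log units; that floor lies within the scatter) from compound 2 to compound 4, at least 6.0-fold (0.77 log units) apart, beyond the scatter of two such steps. Neither step has a known true size, and a single pair of cores gives no general rule, since each comparison includes a compound at the assay limit: the limit of > 60000 nM in this assay, at which 2 of the 4 values shown sit.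

Still open, on these data alone, is how a carboxylic acid in place of ethoxycarbonyl would behave. The same goes for a longer chain in place of prop-1-en-1-yl.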